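The compounds below may be only part of what the source reports. "The series", "measured", "known", "first", "only" and "open" are said of these compounds alone.

Measured compounds:

compound 1 `Cn1c(CN2CCN(c3nc(Cl)ccc3C(F)(F)F)CC2)nc2cc(C(F)(F)F)ccc21` — in an assay on CHO cells with metabotropic glutamate receptor 2 (Homo sapiens) as the target, read by FLIPR (a higher number here means that more compound is needed for the effect, a lower number that less compound is needed), compound 1 gives 2000 nM
compound 2 `Clc1cnc(N2CCN(Cc3nc4ccccc4n3Cc3ccccc3)CC2)nc1` — in this assay compound 2 gives 126 nM

Of the two measured compounds, compound 1 stands at the higher number in this assay, and the gap to compound 2 lies beyond the scatter of repeated measurements; nothing more can be read from that pair, since the two structures differ in several places at once.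

Compound 3 `Cn1c(CN2CCN(c3nc(Cl)ccc3C(F)(F)F)CC2)nc2cc(C#N)ccc21` is the untested neighbour of compound 1. It keeps the whole core of compound 1 and changes one substituent: cyano in place of trifluoromethyl on an aromatic carbon. The benzyl-bearing compound 2 gives no guidance for this exchange, so the expectation rests on the size of the change alone.

A swap of one small substituent for another of the same kind, on the same carbon, is expected to move the number in this assay little, if at all; the step from compound 1 to compound 3 is estimated at a 1.3-fold lower number from compound 1 to compound 3 (0.12 log units; within the scatter), not clearly beyond the scatter in either direction. Compound 3 is therefore expected to give about 1500 nM in this assay, with a plausible range from 400 nM to 6000 nM.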

Compound 3, half-maximal effective concentration: 50.1 nM
Compound 3: middle estimate off by 30-fold (1.48 log units), on the high side; measured number outside the range, below it.
By their numbers in this assay, from the lowest: compound 3; then compound 2; then compound 1.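

In this assay, the aromatic carbon that carries trifluoromethyl in compound 1 proves far from indifferent to what sits on it: exchanging that group for cyano, with the rest of the molecule unchanged, gives a 40-fold lower number from compound 1 to compound 3 (1.60 log units; beyond the scatter) and is the first change in one place alone among the compounds shown. The step shows that a single substituent on this carbon, meta to a fused ring and para to a fused ring, can by itself move the number well beyond the scatter, which the earlier pair, differing in several places at once, could not show. Nothing available here accounts for the size of this step, so its cause remains unassigned.

The compounds shown leave open whether this low number is particular to cyano or whether another group on the same carbon, such as methoxy, a primary amide or plain hydrogen, would give a similar one. They also leave open whether the same exchange would produce a step of similar size if other parts of compound 3 were changed as well.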